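The source may hold more compounds than are shown below. What is called first, only, known or untested is meant among the compounds shown, and "the series" means these compounds.

In an assay on HEK293 cells for displacement of a labelled ligand from NPC1-like intracellular cholesterol transporter 1 (Homo sapiens) (a higher number here means a weaker inhibitor, a lower number a stronger inhibitor), compound 1 `CC(C)(C)c1ccc(C(=O)N2CCC3(CC2)C(=O)N(CC(=O)NCN)CN3c2ccccc2)cc1` gives 26500 nM, compound 2 `CC(C)(C)c1ccc(C(=O)N2CCC3(CC2)C(=O)N(CC(=O)NCCN)CN3c2ccccc2)cc1` gives 7000 nM, and compound 3 `CC1CCCN(C(=O)CN2CN(c3ccccc3)C3(CCN(C(=O)c4ccc(C(C)(C)C)cc4)CC3)C2=O)C1` gives 12000 nM. Among these three numbers compound 3 stands second highest: its nearest neighbour is compound 2, whose number lies within the scatter of it, while compound 1 sits further off, as the step of a 2.2-fold lower number from compound 1 to compound 3 (0.34 log units; beyond the scatter) shows beyond the scatter. Compound 4 `CC(C)(C)c1ccc(C(=O)N2CCC3(CC2)C(=O)N(CC(=O)N2CCC(O)CC2)CN3c2ccccc2)cc1` differs from compound 3 by 4-hydroxypiperidin-1-yl in place of 3-methylpiperidin-1-yl on a carbonyl carbon. For the measured compounds named here, no measured step exchanges one substituent on that ring for another; the steps that touch the same carbonyl carbon are a 2.2-fold lower number from compound 1 to compound 3 (0.34 log units; beyond the scatter) and a 1.7-fold higher number from compound 2 to compound 3 (0.23 log units; within the scatter), and both replace an amino-bearing chain, (aminomethyl)amino or (2-aminoethyl)amino, by the whole ring, the second of them staying within the scatter. The exchange of 3-methylpiperidin-1-yl for 4-hydroxypiperidin-1-yl is a smaller alteration than either of those, so in this assay no step beyond the scatter is expected, the estimate being a 1.3-fold lower number from compound 3 to compound 4 (0.12 log units; within the scatter). Compound 4 is therefore expected to give about 9000 nM in this assay, within a range from 3500 nM to 25000 nM.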

Compound 4, half-maximal inhibitory concentration: 4700 nM
Compound 4: the middle estimate sits 1.9-fold (0.28 log units) above what was measured; measured number inside the range.
By their numbers in this assay, from the lowest: compounds 4, 2 and 3 (each within the scatter of the next, the first and the last beyond it); then compound 1.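

In this assay, for the compounds shown here, this is the first exchange of one substituted ring for another on this carbonyl carbon, and it registers: a 2.6-fold lower number from compound 3 to compound 4 (0.41 log units; beyond the scatter), so this position responds to what the ring carries and not only to whether a ring or an amino-bearing chain is present. Set against those chains, the new ring gives a 5.6-fold lower number from compound 1 to compound 4 (0.75 log units; beyond the scatter), while a 1.5-fold lower number from compound 2 to compound 4 (0.17 log units; within the scatter) stays within the scatter, so an amino-bearing chain is not needed to reach this level among the compounds shown. Nothing available here accounts for these differences.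

Two things change at once from 3-methylpiperidin-1-yl to 4-hydroxypiperidin-1-yl, the group and its place on the ring, so the roles of the hydroxyl and of the methyl remain unseparated. Plain piperidin-1-yl, 4-methylpiperidin-1-yl and 3-hydroxypiperidin-1-yl would pull them apart, and a ring bearing an amine or a carboxylic acid remains open as well.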